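Swapping fluoro for trifluoromethyl on the aryl piperazine

A few compounds are considered here, and "the series" means these few. Any claim that something is new, unique, unknown or untested is made for them only; others in the source may bear on it.

Of the compounds shown here, three that share one core have been tested in a functional assay on the whole organism (strain Swiss) with Mus musculus as the target, in the maximal electroshock model, with a stated time of 1 h, at a dose of 300 mg/kg by the intraperitoneal route; a higher number here means a stronger effect of the compound at the dose given, a lower number a weaker effect. Compound 1 `COCC(C(=O)N1CCN(c2cccc(C(F)(F)F)c2)CC1)N1C(=O)CCC1=O` gives 100% in this assay. Compound 2 `CCC(C(=O)N1CCN(c2cccc(OC)c2)CC1)N1C(=O)CCC1=O` gives 0%. Compound 3 `CCC(C(=O)N1CCN(c2cccc(F)c2)CC1)N1C(=O)CCC1=O` gives 75%, which places compound 3 second of the three numbers, beyond the scatter below compound 1 and beyond the scatter above compound 2. Among the compounds with values here, the only change between measured compounds that differs in a single place is the one from compound 2 to compound 3, a fluoro in place of methoxy on an aromatic carbon, and in this assay it brings a number 75 percentage points higher from compound 2 to compound 3 (beyond the scatter).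

Compound 4 `CCC(C(=O)N1CCN(c2cccc(C(F)(F)F)c2)CC1)N1C(=O)CCC1=O` has not yet been measured. Compared with compound 3 it carries trifluoromethyl in place of fluoro on an aromatic carbon. Within the data shown here, no measured step covers exactly this exchange, so the expectation rests on what the three numbers show. Compound 1 carries the same trifluoromethyl group, though on a different side chain, and reaches 100%, while compound 3 with fluoro already stands high. On that basis compound 4 is expected to reach 90%, somewhere between 60% and 100%, which would mean an expected step of a number 15 percentage points higher from compound 3 to compound 4 (beyond the scatter).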

Compound 4, a percentage reported as activity, at one dose (the size of the read-out at that dose, not a potency): 100%
Compound 4: middle estimate off by 10 percentage points, on the low side, and the stated range covers the measured number.
By their numbers in this assay, from the lowest: compound 2; then compound 3; then compounds 1 and 4 (each within the scatter of the next).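

On this aromatic carbon, trifluoromethyl in place of fluoro brings a number 25 percentage points higher from compound 3 to compound 4 (beyond the scatter) in this assay and trifluoromethyl in place of methoxy brings a number 100 percentage points higher from compound 2 to compound 4 (beyond the scatter) in the same assay. With the side chain held constant, the three compounds now rank in the order methoxy, fluoro, trifluoromethyl, so the earlier methoxy-to-fluoro gain extends one step further. The change on the side chain tells a different story, since methyl in place of methoxy on a saturated chain carbon gives no change at the digits printed from compound 1 to compound 4 (within the scatter) when trifluoromethyl sits on the aromatic ring, and no measurement here offers a reason for either finding.

The compounds shown leave open where a chloro or a nitrile group on this aromatic carbon would fall in that order, and whether a longer chain in place of the methyl on the saturated carbon would keep the read-out unchanged. Each result is also the size of the effect at one dose rather than a potency, so compound 1 and compound 4 could still differ at lower doses.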